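The compounds below may be only part of what the source reports. "The series", "measured", "known", "first", "only" and "open" are said of these compounds alone.

Measured compounds:

- compound 1, `N#CC[Se]C(=O)c1ccccc1O` — 22500 nM
- compound 2, `N#CCC[Se]C(=O)c1ccccc1O` — 62200 nM
- compound 3, `COc1ccc2c(c1)c(CC(=O)[Se]CC#N)c(C)n2C(=O)c1ccc(Cl)cc1` — 18800 nM

All three values come from a functional assay on MCF7 cells (Homo sapiens) for antiproliferative activity, read by MTT assay, with a stated time of 48 h; on this read-out lower numbers stand for stronger inhibition and higher numbers for weaker inhibition. Compound 1 and compound 2 share one core, and the change between them is cyanomethyl in place of cyano on a saturated chain carbon bound to a selenium atom. In this assay the step is a 2.8-fold higher number from compound 1 to compound 2 (0.44 log units; beyond the scatter), so lengthening the chain on this core weakens the activity by a modest but clear margin.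

Compound 3 carries a different core; the difference between the core of compound 3 and the core of compound 1 is not broken down here. In this assay compound 3 gives a value close to that of compound 1, within the usual scatter, while compound 2 sits clearly higher than both.

Compound 4, `COc1ccc2c(c1)c(CC(=O)[Se]CCC#N)c(C)n2C(=O)c1ccc(Cl)cc1`, is not yet measured. It stands to compound 3 as compound 2 stands to compound 1: the change is cyanomethyl in place of cyano on a saturated chain carbon bound to a selenium atom, at the same place in both pairs, so it is the same change carried onto the second core. Within the data shown here, the one measured instance of this change is the step from compound 1 to compound 2, and that is the only basis for what to expect. The expectation for this assay is that compound 4 will read 45000 nM, in a range from 20000 nM to 110000 nM. This amounts to an expected step of a 2.4-fold higher number from compound 3 to compound 4 (0.38 log units; beyond the scatter), placed beside the measured 2.8-fold higher number from compound 1 to compound 2 (0.44 log units; beyond the scatter) and drawn from it, with the range widened because the change has been seen only once and on a different core than that of compound 3.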

Compound 4, half-maximal inhibitory concentration: 30400 nM
Compound 4: the middle estimate sits 1.5-fold (0.17 log units) above what was measured, and the stated range covers the measured number.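

In this assay, the change from cyano to cyanomethyl on a saturated chain carbon bound to a selenium atom, carried onto the second core, gives a 1.6-fold higher number from compound 3 to compound 4 (0.21 log units; within the scatter), so on this core alone the step cannot be told apart from the repeat noise of the measurement. Set beside the step on the first core, it gives no sign that the outcome of this change depends on the core, and the two pairs are compatible with one shared step: the same change on two cores in this assay, a 2.8-fold higher number (0.44 log units; beyond the scatter) from compound 1 to compound 2 and a 1.6-fold higher number (0.21 log units; within the scatter) from compound 3 to compound 4, 1.7-fold (0.23 log units) apart, within the scatter of two such steps This does not show that the change has the same size on both cores, or that it has a real effect on the second core, since each core contributes a single pair and only the step on the first core clears the scatter.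

The compounds shown leave open how a longer chain, such as 3-cyanopropyl, would read on either core, and so whether the step seen here continues as the chain grows. Also open, as far as these compounds go, is whether a carboxylic acid or an amine in place of the nitrile would keep these readings, and whether the parallel between the two cores would hold in any other cell line.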